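Moving the carboxylic acid on the aryl ether end of compound 3

This account rests on a few compounds, and the source may have more. Where it says the series, first, only, none or still open, it means among the compounds named here.

Three compounds sharing a core with a six-membered ether linker and a branched ketone have been tested in an assay on HEK293 cells for positive allosteric modulation of metabotropic glutamate receptor 2 (Rattus norvegicus), read by thallium flux, with a stated time of 2.5 min; a higher number here means a larger maximal response, a lower number a smaller maximal response. Compound 1, `COc1cc(C(=O)O)ccc1OCCCCOc1ccc(C(=O)CC(C)C)c(O)c1C`, gives 85.7%. Compound 2, `Cc1c(OCCCCOc2cccc(C(=O)O)c2)ccc(C(=O)CC(C)C)c1C`, gives 12.1%. Compound 3, `Cc1c(OCCCCOc2ccc(C(=O)O)c(Cl)c2)ccc(C(=O)CC(C)C)c1O`, gives 80.5%, which is the second highest of the three numbers: its gap to compound 1 lies within the scatter, so no order between them is claimed, while its gap to compound 2 lies well beyond it.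

Compound 4, `Cc1c(OCCCCOc2cccc(C(=O)O)c2)ccc(C(=O)CC(C)C)c1O`, has not yet been measured. It differs from compound 3 in one place: 3-carboxyphenyl in place of 4-carboxy-3-chlorophenyl on an oxygen on a saturated carbon. Compound 2 also bears a 3-carboxyphenyl group, and its number in this assay is low. For the measured compounds named here, compound 2 does not share the core of compound 3, and no step between the two is available, so its low number is read only as a hint. Going by the values given here, no step between measured compounds of this kind is available, so the direction can only be guessed.

On balance a decrease beyond the scatter is expected, with a step of a number 30.5 percentage points lower from compound 3 to compound 4 (beyond the scatter). Compound 4 is therefore estimated to reach 50%, in a range from 15% to 85%.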

Compound 4, largest response reached (reported as percent of maximum), in percent of the reference or control that the assay uses: 84.5%
The estimate for compound 4 lay 34.5 percentage points below the measured number; low and high end bracket the measured number.
By their numbers in this assay, from the lowest: compound 2; then compounds 3, 4 and 1 (each within the scatter of the next).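

In this assay, placing 3-carboxyphenyl where 4-carboxy-3-chlorophenyl stood, on an oxygen on a saturated carbon, gives a number 4 percentage points higher from compound 3 to compound 4 (within the scatter), so the two groups cannot be told apart at this position in this series. The 3-carboxyphenyl group therefore does not by itself go with a low maximal response, as the low number of compound 2 alone had left possible. The large difference appears instead with the other single change, hydroxy in place of methyl on an aromatic carbon, which gives a number 72.4 percentage points higher from compound 2 to compound 4 (beyond the scatter); nothing shown explains why this change has so large an effect or why the exchange at the ether end has so little.

The compounds shown leave open whether hydroxy in place of methyl has the same effect when 4-carboxy-3-chlorophenyl sits at the ether end, and whether an amine on that aromatic carbon would behave like the hydroxy or like the methyl. They also leave open whether the response would hold with a tetrazole in place of the carboxylic acid, or with a longer chain joining the two aryl ethers.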